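This account rests on a few compounds, and the source may have more. Where it says the series, first, only, none or still open, it means among the compounds named here.

Compound 1 `Cc1cc(-c2ccc(O)cc2)c2ncc(CSCCc3ccccc3)n2c1`: 13.7 ug/mL
Compound 2 `Cc1cc(-c2ccc(O)cc2)cn2c(CSCCc3ccccc3)cnc12`: > 50 ug/mL
Compound 3 `Cc1cc(-c2ccsc2)cn2c(CSCCc3ccccc3)cnc12`: > 50 ug/mL

All three compounds were tested in an ADME assay on HEL cells (Homo sapiens) for cytotoxicity, with a stated time of 3 days; on this read-out higher numbers stand for lower toxicity in this test and lower numbers for higher toxicity in this test. Going by the values given here, compound 1 gives 13.7 ug/mL in this assay, and this is the only number among the three read-outs. For compound 2 the read-out is a limit of the assay, > 50 ug/mL. For compound 3 the read-out is likewise a limit of the assay, > 50 ug/mL. Among the compounds with values here, the single pair that differs in one place gives a step that the two limits leave unreadable from compound 2 to compound 3, a step that cannot be read, since the limit of > 50 ug/mL in this assay, at which 2 of the 3 values shown sit, is where both of its ends sit. Compound 1 and compound 2 differ in the arrangement of the shared core; their values show only a number against a limit.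

Compound 4 `COc1ccc(-c2cc(C)cn3c(CSCCc4ccccc4)cnc23)cc1` has not yet been measured. Compared with compound 1 it carries methyl in place of hydrogen on an oxygen on an aromatic ring. Within the data shown here, no measured step covers the change from hydroxy to methoxy, and the only step that exists is unreadable, so nothing measured bears directly on compound 4. Resting on the value of compound 1 alone, compound 4 is expected to show a 1.5-fold higher number from compound 1 to compound 4 (0.16 log units; within the scatter). The estimate for compound 4 in this assay is 20 ug/mL, with a range from 8 ug/mL to 50 ug/mL.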

Compound 4, half-maximal cytotoxic concentration: 19.6 ug/mL
Compound 4: middle estimate off by 1.0-fold (0.01 log units), on the high side, within the range that was stated.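

In this assay, the change from hydroxy to methoxy gives the only step among these compounds that can be read, a 1.4-fold higher number from compound 1 to compound 4 (0.16 log units; within the scatter). Going by these compounds alone, for this one pair, on the core of compound 1, methyl in place of hydrogen on an oxygen on an aromatic ring therefore moves the read-out by no more than the usual scatter of repeated measurements, something the earlier compounds could not show. The step from compound 2 to compound 3 still cannot be read, because both of its ends sit at the same limit, so it says nothing about how the 4-hydroxyphenyl group can be replaced: the limit of > 50 ug/mL in this assay, at which 2 of the 4 values shown sit.

The compounds shown leave open whether the change from hydroxy to methoxy would read the same on the core of compound 2, whose own read-out is only a limit. They also leave open whether a larger change at this oxygen or on this ring, such as a longer chain in place of the methyl or an amine or a carboxylic acid in place of the hydroxy, would stay within the scatter.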